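The source may report more compounds than this note shows. Statements on the series, on what has been measured and on what is new or still open speak of the compounds shown alone.

Of the compounds shown here, three built on one shared core have been measured in an assay on isolated protein for inhibition of RAC-alpha serine/threonine-protein kinase (Homo sapiens), read by mobility shift assay, tested at 30 uM; on this read-out higher numbers stand for more inhibition at the one concentration tested (going by the name of the read-out) and lower numbers for less inhibition. Compound 1 `Cc1cc2[nH]nc(N)c2c(=O)[nH]1` gives -3% in this assay. Compound 2 `Nc1n[nH]c2cc(-c3ccccn3)[nH]c(=O)c12` gives 2%. Compound 3 `COc1ccc(-c2cc3[nH]nc(N)c3c(=O)[nH]2)cc1` gives 21%, the highest of the three numbers; its gap to compound 2 and its gap to compound 1 both lie beyond the usual scatter, so compound 3 stands clearly above the other two on this read-out.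

Compound 4 `CN1CCN(c2ccc(-c3cc4[nH]nc(N)c4c(=O)[nH]3)cc2)CC1` has not yet been measured. It differs from compound 3 in a single place: 4-methylpiperazin-1-yl in place of methoxy on an aromatic carbon. Within the data shown here, no two measured compounds differ in only one place, so no measured step shows what such an exchange does on this core. The numbers shown give only a weak guide: the larger the group on the shared core, the higher the number, with compound 3 the largest and the highest of the three.

On that basis the step is expected to be small, in the upward direction or none beyond the scatter, estimated as a number 9 percentage points higher from compound 3 to compound 4 (within the scatter). Compound 4 is expected to give 30% in this assay, with a range from 5% to 55%.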

Compound 4, a percentage reported as inhibition, at one concentration (the size of the read-out at that concentration, not a potency): 9%
Compound 4: middle estimate off by 21 percentage points, on the high side; the measured number falls inside the stated range.
By their numbers in this assay, from the lowest: compounds 1, 2 and 4 (each within the scatter of the next, the first and the last beyond it); then compound 3.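

In this assay, among these compounds, the first step in a single place on the shared core is a number 12 percentage points lower from compound 3 to compound 4 (beyond the scatter) when 4-methylpiperazin-1-yl takes the place of methoxy on an aromatic carbon, para to a large group. At this position, then, the larger group with its six-membered non-aromatic ring does not bring more inhibition at the one concentration tested, and the smaller methoxy keeps the higher number, so size alone does not raise the read-out in this exchange. Nothing given here accounts for the drop.

The compounds shown leave open whether the lower number goes with the whole ring, with its two nitrogens or with the methyl group on the ring, since a morpholine, an unsubstituted piperazine or a simple dimethylamino group at the same place would separate these parts. They also leave open whether a small group other than methoxy, such as a hydroxyl, a fluorine or a carboxylic acid, would hold or raise the number on this aromatic carbon.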